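Swapping a methoxymethyl for a 1-bromoethyl on the amide carbonyl

This account rests on a few compounds, and the source may have more. Where it says the series, first, only, none or still open, it means among the compounds named here.

Three compounds sharing one core were tested in a functional assay on HCT-116 cells (Homo sapiens) for inhibition, read by MTT assay, with a stated time of 48 h; a higher number here means a weaker inhibitor, a lower number a stronger inhibitor. Compound 1 `COc1ccc(CN(C(=O)C2CC2)c2cc(OC)c(OC)c(OC)c2)cc1O` gives 49 nM. Compound 2 `COc1ccc(CN(C(=O)CCCCCl)c2cc(OC)c(OC)c(OC)c2)cc1O` gives 220 nM. Compound 3 `COCC(=O)N(Cc1ccc(OC)c(O)c1)c1cc(OC)c(OC)c(OC)c1` gives 230 nM, the highest of the three numbers, within the scatter of compound 2 but clearly weaker than compound 1, as a 4.7-fold higher number from compound 1 to compound 3 (0.67 log units; beyond the scatter) shows. Compound 4 `COc1ccc(CN(C(=O)C(C)Br)c2cc(OC)c(OC)c(OC)c2)cc1O` carries a different group: 1-bromoethyl in place of methoxymethyl on a carbonyl carbon. Among the measured compounds shown here, no measured step tests this exact exchange. The nearest guide is a 1.0-fold higher number from compound 2 to compound 3 (0.02 log units; within the scatter), where a methoxy and a chloroalkyl chain gave the same result, while a 4.5-fold higher number from compound 1 to compound 2 (0.65 log units; beyond the scatter) and a 4.7-fold higher number from compound 1 to compound 3 (0.67 log units; beyond the scatter) were both modest losses. A step of a 1.2-fold lower number from compound 3 to compound 4 (0.06 log units; within the scatter) is therefore expected, staying within the scatter. Compound 4 is estimated at 200 nM, between 80 nM and 500 nM.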

Compound 4, half-maximal inhibitory concentration: 140 nM
The estimate for compound 4 lay 1.4-fold (0.15 log units) above the measured number; the measured number falls inside the stated range.
By their numbers in this assay, from the lowest: compound 1; then compounds 4, 2 and 3 (each within the scatter of the next).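

Placing bromine in the 1-bromoethyl group on this carbonyl carbon leaves compound 4 level with the other open-chain compounds, with a 1.6-fold lower number from compound 3 to compound 4 (0.22 log units; within the scatter) and a 1.6-fold lower number from compound 2 to compound 4 (0.20 log units; within the scatter) both small. The cyclopropyl of compound 1 still stands apart, with a 2.9-fold higher number from compound 1 to compound 4 (0.46 log units; beyond the scatter). Nothing in the available data explains why these groups rank this way.

On these data alone, whether a cyclobutyl ring or an amine on the chain would match compound 1 remains open. So does whether a plain ethyl group would sit with compound 4.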